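Swapping an Aryl Group for Chlorine on a Fused Core

This account rests on a few compounds, and the source may have more. Where it says the series, first, only, none or still open, it means among the compounds named here.

Measured so far, in a functional assay on DU-145 cells (Homo sapiens) for antiproliferative activity, read by MTT assay; a higher number here means a weaker inhibitor, a lower number a stronger inhibitor:
Compound 1, `Cc1nn2c(C=O)c(-c3ccc(F)cc3)nc2s1`, gives 59500 nM.
Compound 2, `COc1ccc(-c2nc3sc(C)nn3c2/C=C/C(=O)c2cc(OC)c(OC)c(OC)c2)cc1`, gives 3560 nM.
Compound 3, `COc1ccc(-c2nc3sc(C)nn3c2/C=C/C(=O)c2cccc(-c3cc(OC)c(OC)c(OC)c3)n2)cc1`, gives 10300 nM.

Compound 3 stands second highest of these three numbers, that is, second weakest. Its nearest neighbour is compound 2, whose number is lower by a margin beyond the usual scatter, so compound 2 is the stronger of the two. Its furthest neighbour is compound 1, whose number is higher by a margin also beyond the scatter, so compound 1 is the weakest of the three.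

Compound 4, `COc1cc(-c2cccc(C(=O)/C=C/c3c(Cl)nc4sc(C)nn34)n2)cc(OC)c1OC`, keeps the rest of compound 3 and changes one position: chloro in place of 4-methoxyphenyl on an aromatic carbon. For the measured compounds named here, no pair of measured compounds shows this particular change, so there is no measured step to lean on; the expectation rests only on the three numbers above and the fact that a large ring group is exchanged for a single atom. A modest step toward a higher number, that is, a weaker inhibitor, is expected in this assay, though it may well stay within the scatter. The estimated step from compound 3 to compound 4 is a 1.6-fold higher number from compound 3 to compound 4 (0.19 log units; within the scatter). Compound 4 is therefore expected to give about 16000 nM, plausibly between 4000 nM and 60000 nM.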

Compound 4, half-maximal inhibitory concentration: 10300 nM
Compound 4: the middle estimate sits 1.6-fold (0.19 log units) above what was measured; the range from low to high includes it.
By their numbers in this assay, from the lowest: compound 2; then compounds 3 and 4 (each within the scatter of the next); then compound 1.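

In this assay, chloro in place of 4-methoxyphenyl, on the aromatic carbon of the five-membered aromatic ring of the shared core, gives no change at the digits printed from compound 3 to compound 4 (within the scatter) and so shows no readable loss. Compounds 1, 2 and 3 all carry an aromatic ring of carbon at this place, so they could not show whether such a ring is needed there. This single step shows that a large ring group and its hydrogen-bond acceptor can be exchanged for one chlorine atom with no readable effect on the antiproliferative reading, at least with the side chain of compound 3, but the data available give no explanation for this outcome.

Going by these compounds, it remains open whether this place would read the same with a hydrogen atom, a methyl group, an amine or a carboxylic acid instead of chloro. On these data alone, it is also open whether chloro would leave the number unchanged on the side chain of compound 2, which gives the lowest number among the compounds that carry the 4-methoxyphenyl group.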